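Extending a phenol into a hydroxypropyl ether

A few compounds are considered here, and "the series" means these few. Any claim that something is new, unique, unknown or untested is made for them only; others in the source may bear on it.

Compound 1 `Cc1cc(OCC(=O)N(C)C)cc(C)c1-c1cccc(COc2ccc(OCC(=O)O)c(F)c2)c1` has no number in a physicochemical assay for lipophilicity, using the shake flask method, in phosphate buffer, measured as octanol-water partition, with a stated time of 24 h, at pH 7.4, tested at 100 uM; a lower number here means a more polar compound, a higher number a more lipophilic compound; its entry reads "not determined" (no result reported). Among the measured compounds shown here, compound 2 `Cc1cc(O)cc(C)c1-c1cccc(COc2ccc(OCC(=O)O)c(F)c2)c1` holds the only value shown, and in this assay compound 2 gives 2.37. Compound 3 `Cc1cc(OCCCO)cc(C)c1-c1cccc(COc2ccc(OCC(=O)O)c(F)c2)c1` differs from compound 2 in one place: 3-hydroxypropyl in place of hydrogen on an oxygen on an aromatic ring. For the measured compounds named here, no step between two measured compounds is known here, so the size of this change has to be estimated. The expected step of a number 0.23 log units higher from compound 2 to compound 3 (within the scatter) is a modest rise, roughly at the edge of the usual scatter. Compound 3 is therefore expected to give about 2.6, within a range from 2.1 to 3.1.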

Compound 3, distribution coefficient: 2.73
Compound 3: the middle estimate sits 0.13 log units below what was measured; measured number inside the range.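

In this assay, among the compounds shown here, the change gives a number 0.36 log units higher from compound 2 to compound 3 (beyond the scatter), the only step available at this position, and it shows that putting 3-hydroxypropyl in place of hydrogen on this oxygen moves the number by more than ordinary scatter. No measurement shown here explains the size of this step. A single step cannot show whether the number keeps moving as the chain grows. From the compounds shown here alone, how a longer chain, or a chain ending in an amine, on the same oxygen would read remains open.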